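This account rests on a few compounds, and the source may have more. Where it says the series, first, only, none or still open, it means among the compounds named here.

Compound 1 `COc1ccc(C(=O)/C=C/c2cc3ccccc3[nH]c2=O)cc1` and compound 2 `O=C(/C=C/c1cc2ccccc2[nH]c1=O)c1ccc(O)cc1` share one core and differ by a single group. In an ADME assay on SR cells (Homo sapiens) for cytotoxicity, read by sulforhodamine B assay, with a stated time of 24 h (on this read-out higher numbers stand for lower toxicity in this test and lower numbers for higher toxicity in this test), compound 1 gives only a limit of the assay, > 100000 nM. In this assay compound 2 likewise gives only a limit, > 100000 nM. Within the data shown here, the one measured step here, a step that the two limits leave unreadable from compound 1 to compound 2, has both of its ends at a limit, and its size cannot be read. Among the measured compounds shown here, the one piece of evidence that remains is the limit of > 100000 nM in this assay, at which 2 of the 2 values shown sit. For the measured compounds named here, compound 2 therefore stands at that limit with no number of its own; no compound in the set shows a number in this assay.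

Compound 3 `O=C(/C=C/c1cc2ccccc2[nH]c1=O)c1ccc(Cl)cc1` differs from compound 2 by chloro in place of hydroxy on an aromatic carbon. No measured step covers a change of this kind, and the single shown step has no readable size, so nothing here supports expecting compound 3 to move off the limit in either direction. The expected step of a number no higher from compound 2 to compound 3 (the limit leaves the size open) is thus not beyond the scatter. Compound 3 is estimated at 100000 nM, within a range from 30000 nM to 300000 nM, and is expected most often to be reported again only as a limit.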

Compound 3, concentration lethal to 50% of the cells: > 100000 nM
Compound 3 gave a limit, no number; the forecaster's own chance of this, stated with the estimate: 70%; the middle value sits exactly at the limit.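

Compound 1, compound 2 and compound 3 each give only a limit in this assay, so the steps among these three compounds cannot be read. The compounds shown leave open where each would fall on a readable number, and whether hydroxy, methoxy or chloro on the aromatic ring makes any difference in this assay.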